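The source may report more compounds than this note shows. Statements on the series, on what has been measured and on what is new or still open speak of the compounds shown alone.

Of the compounds shown here, two have so far been tested in an assay on a protein complex (Cavia porcellus) with sulfonylurea receptors; K-ATP channels (Homo sapiens) as the target; on this read-out lower numbers stand for stronger inhibition and higher numbers for weaker inhibition. Compound 1 `CCN(CC)C(=O)c1ccc(NC(=O)C(C)(O)C(F)(F)F)cc1` reaches only a limit of the assay, reported as > 30000 nM. Compound 2 `CC(C)CN(CC(C)C)S(=O)(=O)c1ccc(NC(=O)C(C)(O)C(F)(F)F)cc1` likewise reaches only a limit of the assay, reported as > 30000 nM. Among the compounds with values here, compound 2 thus sits at the limit of > 30000 nM in this assay, at which 2 of the 2 values shown sit, and no measured step between the two compounds exists. Compound 3 `CC(O)(C(=O)Nc1ccc(S(=O)(=O)N2CCOCC2)cc1)C(F)(F)F` differs from compound 2 by morpholin-4-yl in place of diisobutylamino on a sulfonyl sulfur. With both measured values sitting at the limit, the step of a number no higher from compound 2 to compound 3 (the limit leaves the size open) is expected to be none beyond the scatter. Compound 3 is therefore estimated at 30000 nM, within a range from 10000 nM to 100000 nM.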

Compound 3, half-maximal inhibitory concentration: 5850 nM
For compound 3 the middle estimate is 5.1-fold (0.71 log units) above the measured one; measured number outside the range, below it.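

In this assay, the group on the sulfonyl sulfur proves able to move the read-out: morpholin-4-yl in place of diisobutylamino gives an at least 5.1-fold lower number from compound 2 to compound 3 (0.70 log units; beyond the scatter). Within the data shown here, compound 3 is the first compound here with a value that is a number and not a limit of the assay. Because compound 2 remains at a limit, the full size of this step stays unknown: the limit of > 30000 nM in this assay, at which 2 of the 3 values shown sit.

As far as these compounds go, whether the gain comes from the ring, its oxygen or the smaller group stays open. A piperidin-1-yl or dimethylamino group on the same sulfonyl sulfur would help to separate these.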